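Sulfonyl aryl variation and metabolic stability in a biaryl series

The source may report more compounds than this note shows. Statements on the series, on what has been measured and on what is new or still open speak of the compounds shown alone.

Working notes on the series. All members share one core carrying a sulfonyl aryl group, and the measure tracked is an ADME assay on microsomes from liver (Homo sapiens) for metabolic stability, tested at 2.5 uM; a lower number here means slower removal, a higher number faster removal of the compound. Compound 1 `Cc1ccc(S(=O)(=O)c2cnc3cc(F)ccc3c2-c2ccc(F)cc2)cc1C` gives 9.25 mL/min in this assay. Compound 2 `O=S(=O)(c1ccc(F)c(Cl)c1)c1cnc2cc(F)ccc2c1-c1ccc(F)cc1` gives 0.69 mL/min, and compound 3 `O=S(=O)(c1ccc(F)cc1)c1cnc2cc(F)ccc2c1-c1ccc(F)cc1` gives 1.34 mL/min. Compound 3 therefore sits well below compound 1, by a 6.9-fold lower number from compound 1 to compound 3 (0.84 log units; beyond the scatter), and close to compound 2, the gap being a 1.9-fold higher number from compound 2 to compound 3 (0.29 log units; within the scatter). The largest movement among the measured pairs is a 13-fold lower number from compound 1 to compound 2 (1.13 log units; beyond the scatter).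

Compound 4 `Cc1ccc(S(=O)(=O)c2cnc3cc(F)ccc3c2-c2ccc(F)cc2)cc1F` is the next member and is not yet measured. Relative to compound 3 the change is 3-fluoro-4-methylphenyl in place of 4-fluorophenyl on a sulfonyl sulfur. Structurally this puts compound 4 between compound 3 and compound 1, since one methyl of the 3,4-dimethylphenyl of compound 1 is present while the fluorine of compound 3 remains. The step that bears most is a 6.9-fold lower number from compound 1 to compound 3 (0.84 log units; beyond the scatter), where removing both methyls cut the number strongly; the step of a 1.9-fold higher number from compound 2 to compound 3 (0.29 log units; within the scatter) shows that a chloro to hydrogen swap mattered little. A partial reversal of the first step is expected for compound 4, smaller than the full gap to compound 1. The expected step is a 2.2-fold higher number from compound 3 to compound 4 (0.35 log units; beyond the scatter). Compound 4 is thus estimated at 3 mL/min, within a range from 1.3 mL/min to 7 mL/min.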

Compound 4, intrinsic clearance in a liver preparation (reported as CLH), per the amount of preparation that the assay uses: 2.33 mL/min
Compound 4: the middle estimate sits 1.3-fold (0.11 log units) above what was measured; measured number inside the range.
By their numbers in this assay, from the lowest: compounds 2, 3 and 4 (each within the scatter of the next, the first and the last beyond it); then compound 1.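

On the sulfonyl sulfur, 3-fluoro-4-methylphenyl cannot be told apart from 4-fluorophenyl in this assay, the step being a 1.7-fold higher number from compound 3 to compound 4 (0.24 log units; within the scatter); it does stand apart from 3-chloro-4-fluorophenyl, with a 3.4-fold higher number from compound 2 to compound 4 (0.53 log units; beyond the scatter), even though compound 3 lies within the scatter of both compound 2 and compound 4. The sharpest new reading is that one fluoro in place of methyl on an aromatic carbon already gives a 4.0-fold lower number from compound 1 to compound 4 (0.60 log units; beyond the scatter), so a single swap on this aryl group accounts for a clear change, whereas the earlier step to 4-fluorophenyl altered both substituents at once and could not show this. Nothing at hand bears on why these numbers fall as they do.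

Still open, from the compounds shown here alone, is how 4-methylphenyl, with methyl as the only substituent on the ring, would read on the sulfonyl sulfur, which would show how much the fluoro contributes in the 3-fluoro-4-methylphenyl group. Also open, going by these compounds, is how far this reading carries to groups of another kind on that aryl ring, such as an amine, a carboxylic acid or an ethyl chain in place of the methyl.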